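Aryl swap at the shared core: compound 2 to compound 3

This account rests on a few compounds, and the source may have more. Where it says the series, first, only, none or still open, it means among the compounds named here.

Measured so far:
compound 1, `Cc1cccc(-c2noc([C@@H](C)NC(=O)c3cc(C4CC4)nn3C)n2)c1`: in an assay on T-REx-293 cells for inhibition of potassium channel subfamily T member 1 (Homo sapiens), read by patch clamp (on this read-out higher numbers stand for weaker inhibition and lower numbers for stronger inhibition), compound 1 gives 3310 nM
compound 2, `Cc1cc(-c2noc([C@H](C)NC(=O)c3cc(C(F)(F)F)nn3C)n2)ncn1`: in this assay compound 2 gives 1410 nM

Compound 2 holds the lower of the two numbers; compound 1 sits above it by a step beyond the usual scatter. Compound 3, `C[C@H](NC(=O)c1cc(C(F)(F)F)nn1C)c1nc(-c2ccnc(C(F)F)c2)no1`, is not yet measured. It differs from compound 2 by a group of 9 heavy atoms (6 carbon, 1 nitrogen, 2 fluorine; one six-membered aromatic ring with 1 hetero atom) in place of a group of 7 heavy atoms (5 carbon, 2 nitrogen; one six-membered aromatic ring with 2 hetero atoms), on an aromatic carbon. Among the compounds with values here, no measured pair shows this change, so its step size is unknown from the series. A modest step in this assay toward a lower number is expected, though it may stay within the scatter. Compound 3 is expected near 800 nM (range 250 nM to 3000 nM), an expected step of a 1.8-fold lower number from compound 2 to compound 3 (0.25 log units; within the scatter).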

Compound 3, half-maximal inhibitory concentration: 61 nM
Compound 3: middle estimate off by 13-fold (1.12 log units), on the high side, and the stated range ends above it.
By their numbers in this assay, from the lowest: compound 3; then compound 2; then compound 1.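

In this assay, within the data shown here, the aromatic carbon of the five-membered aromatic ring with 2 nitrogen and 1 oxygen proves sensitive to the group it carries: the group of 9 heavy atoms in place of 6-methylpyrimidin-4-yl gives a 23-fold lower number from compound 2 to compound 3 (1.36 log units; beyond the scatter) and provides the first one-place comparison. No supporting measurement accounts for the size of this step. This single change alters the ring hetero atoms, the methyl group and the fluorine content together, leaving their separate contributions unresolved. A nitrile or methoxy group on the pyridine ring would test whether the fluorine atoms are needed.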